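Piperidine substituent swap in a cinnamamide series

The compounds below may be only part of what the source reports. "The series", "measured", "known", "first", "only" and "open" are said of these compounds alone.

Of the compounds shown here, three of the shared core have been measured in a functional assay on CHO-K1 cells for antagonist activity at melanin-concentrating hormone receptor 1 (Homo sapiens), read by inositol phosphate accumulation, with stated times of 10 min and 45 min; a lower number here means a stronger inhibitor, a higher number a weaker inhibitor. Compound 1 `Cc1nc(N2CCC(O)CC2)nc2ccc(NC(=O)/C=C/c3ccc(Cl)cc3)cc12` gives 73 nM. Within the data shown here, compound 3 `C/C(=C\C(=O)Nc1ccc2nc(N3CCC(O)CC3)nc(C)c2c1)c1ccc(Cl)cc1` gives 227 nM, and the change a 3.1-fold higher number from compound 1 to compound 3 (0.49 log units; beyond the scatter) is the only single-point step on record. Compound 2 `Cc1nc(N2CCC(N3CCCS3(=O)=O)CC2)nc2ccc(NC(=O)/C=C/c3ccc(OC(F)(F)F)cc3)cc12` gives 16 nM, the lowest of the three numbers, with compound 1 nearest and compound 3 furthest.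

Compound 4 `COCC(=O)NC1CCN(c2nc(C)c3cc(NC(=O)/C=C/c4ccc(OC(F)(F)F)cc4)ccc3n2)CC1` is the next candidate. Its difference from compound 2 is a group of 6 heavy atoms (3 carbon, 1 nitrogen, 2 oxygen; no ring) in place of a group of 7 heavy atoms (3 carbon, 1 nitrogen, 2 oxygen, 1 sulfur; one five-membered non-aromatic ring with 2 hetero atoms), on a saturated ring carbon. Among the measured compounds shown here, no measured step touches this position: compound 1 and compound 2 differ both on the saturated ring carbon and on the aryl ring, so their values cannot be assigned to either change. The step from compound 1 to compound 3 concerns the linker and does not bear on this substitution. For the measured compounds named here, with no direct precedent, a step in this assay close to the scatter is expected, drifting if at all toward a higher number. Compound 4 is therefore expected near 25 nM, within 8 nM to 80 nM. The expected step is a 1.6-fold higher number from compound 2 to compound 4 (0.19 log units; within the scatter).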

Compound 4, half-maximal inhibitory concentration: 14 nM
Compound 4: middle estimate off by 1.8-fold (0.25 log units), on the high side; the measured number falls inside the stated range.
By their numbers in this assay, from the lowest: compounds 4 and 2 (each within the scatter of the next); then compound 1; then compound 3.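

In this assay, the ((methoxymethyl)carbonyl)amino group takes the place of the group of 7 heavy atoms with its five-membered non-aromatic ring, giving a 1.1-fold lower number from compound 2 to compound 4 (0.06 log units; within the scatter). Among these compounds, this is the first step that isolates the saturated ring carbon, since the rest of the structure is held constant. In this pair, losing the ring and gaining a hydrogen-bond donor leaves the number within the scatter, and nothing on record explains why the two groups read alike.

Compounds 1 and 2 differ in two places, so the effect of the hydroxy group against these larger groups on this carbon cannot be read. Going by these compounds, it also remains open how an amine or a carboxylic acid on this carbon would read, or a longer chain in place of the methoxymethyl part, and whether the match between these two groups holds with the 4-chlorophenyl of compound 1.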